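Adding a methoxy group to a level pair

The source may report more compounds than this note shows. Statements on the series, on what has been measured and on what is new or still open speak of the compounds shown alone.

Compound 1 `COc1cccc2cc(-c3ccccc3)c(O)nc12` gives 10000 nM in a functional assay on PC-3 cells (Homo sapiens) for cytotoxicity, read by colorimetric assay and MTT assay (a lower number here means a stronger inhibitor, a higher number a weaker inhibitor), and compound 2 `COc1ccc2cc(-c3ccccc3)c(O)nc2c1` gives 10000 nM there, so compound 2 stands level with compound 1 at the digits shown, within the scatter. Compound 3 `COc1cc(OC)c2cc(-c3ccccc3)c(O)nc2c1` differs from compound 2 in a single place: methoxy in place of hydrogen on an aromatic carbon with methoxy in place of hydrogen on an aromatic carbon, meta to the methoxy group already present. For the measured compounds named here, the two measured compounds share one level and offer no step to extrapolate from, so little supports a large move in this assay either way. The expected result is no change beyond the scatter, with a slight lean toward stronger inhibition: the estimated 1.3-fold lower number from compound 2 to compound 3 (0.10 log units; within the scatter) stays small. Estimated for compound 3: 8000 nM as the middle, with 2500 nM to 20000 nM as the expected range.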

Compound 3, half-maximal inhibitory concentration: 10000 nM
Compound 3: middle estimate off by 1.3-fold (0.10 log units), on the low side; low and high end bracket the measured number.
By their numbers in this assay, from the lowest: compounds 1, 2 and 3 (each within the scatter of the next).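

In this assay, for the compounds shown here, methoxy in place of hydrogen on an aromatic carbon, meta to a methoxy group, gives no change at the digits printed from compound 2 to compound 3 (within the scatter) and is the first step that changes a single place. At this position, then, the added methoxy group leaves the read-out flat, something the earlier level pair could not show without a step between measured compounds. Nothing on hand bears on the reason for this flat result.

One step at one position cannot tell whether another group here, such as an amine, a carboxylic acid or a longer alkoxy chain, would move the number beyond the scatter. Also open, from the compounds shown here alone, is whether the same methoxy change would read the same way on the core of compound 1.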